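This account rests on a few compounds, and the source may have more. Where it says the series, first, only, none or still open, it means among the compounds named here.

For the measured compounds named here, in a functional assay on A-375 cells (Homo sapiens) for inhibition, read by CCK-8 assay, with a stated time of 72 h, tested at 8 uM (a higher number here means more inhibition of growth at the concentration tested, a lower number less inhibition of growth), two compounds have numbers so far. Compound 1 (`Nc1ccccc1NC(=O)/C=C/c1ccc(CSc2cccc(F)c2)cc1`) gives 9.08%, and compound 2 (`Nc1ccccc1NC(=O)c1ccc(CSc2cccc(F)c2)cc1`) gives 76.3%. Compound 2 therefore stands highest of the two. The gap to compound 1 lies beyond the scatter of such measurements.

Compound 3 (`Cc1cc(C)cc(SCc2ccc(C(=O)Nc3ccccc3N)cc2)c1`) has not yet been measured. It carries 3,5-dimethylphenyl in place of 3-fluorophenyl on a sulfur, and the counted difference is 3,5-dimethylphenyl in place of 3-fluorophenyl on a sulfur. The rest of compound 2 stays as it is. Going by the values given here, no measured pair yet shows what a change at this place does, so the expectation rests on little.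

A small fall in this assay is expected, one that would most likely stay within the scatter. Compound 2 already stands at 76.3%, which leaves more room for a large drop than for a large rise, so the range is drawn wider on the lower side. The expected change is a number 8.3 percentage points lower from compound 2 to compound 3 (within the scatter). For compound 3 the estimated value is 68%, with an expected range of 42% to 86%.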

Compound 3, percent growth inhibition at one concentration: 74.7%
For compound 3 the middle estimate is 6.7 percentage points below the measured one, and the stated range covers the measured number.
By their numbers in this assay, from the lowest: compound 1; then compounds 3 and 2 (each within the scatter of the next).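

In this assay, putting 3,5-dimethylphenyl in place of 3-fluorophenyl on a sulfur gives a number 1.6 percentage points lower from compound 2 to compound 3 (within the scatter), the first step read at this position. In this one case, then, the fluorine can go and two methyl groups can come onto the ring without a change beyond the scatter, so the position is not shown to be sensitive to this exchange. No independent measurement bears on why the two aryl groups read alike.

The compounds shown place only these two aryl groups on the sulfur, and a single step cannot say how an unsubstituted phenyl, a pyridine, or a ring bearing an amine or a carboxylic acid would read there. On these data alone, it also remains open whether the same tolerance would hold for a group of a different kind, such as a cyclohexyl ring or a longer chain in place of the aryl group, or with an oxygen standing where the sulfur now stands.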